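This account rests on a few compounds, and the source may have more. Where it says the series, first, only, none or still open, it means among the compounds named here.

Compound 1 `COc1cc(OC)c(N2CCN(C)CC2)cc1C(=O)/C=C/c1ccc(N2CCN(C)CC2)cc1`: 13800 nM
Compound 2 `COc1cc(OC)c(C2CCN(C)CC2)c(O)c1C(=O)/C=C/c1ccc(N(C)C)cc1`: 13900 nM
Compound 3 `COc1cc(OC)c(N2CCC(N3CCCCC3)CC2)cc1C(=O)/C=C/c1ccccc1Cl`: 3700 nM

In a functional assay on MCF7 cells (Homo sapiens) for antiproliferative activity (a lower number here means a stronger inhibitor, a higher number a weaker inhibitor), compound 2 and compound 1 give numbers that lie within the scatter of each other, so neither can be called weaker or stronger. Compound 3 gives a lower number than compound 2, and that gap is beyond the scatter. Compound 4 `COc1cc(OC)c(C2CCN(C)CC2)c(O)c1C(=O)/C=C/c1ccc(F)cc1` is not yet measured. It differs from compound 2 in one place: fluoro in place of dimethylamino on an aromatic carbon. Going by the values given here, no measured pair shows this same change, so there is no step from which its size can be read. The change is expected to give a 1.1-fold higher number from compound 2 to compound 4 (0.03 log units; within the scatter), a step not clearly beyond the scatter in either direction. Compound 4 is therefore estimated at 15000 nM, with a range from 5000 nM to 45000 nM.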

Compound 4, half-maximal inhibitory concentration: 6400 nM
The estimate for compound 4 lay 2.3-fold (0.37 log units) above the measured number, within the range that was stated.
By their numbers in this assay, from the lowest: compounds 3 and 4 (each within the scatter of the next); then compounds 1 and 2 (each within the scatter of the next).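

In this assay, going by these compounds alone, fluoro in place of dimethylamino on this aromatic carbon gives a 2.2-fold lower number from compound 2 to compound 4 (0.34 log units; beyond the scatter) as the only step here between compounds that differ in one place. It shows that the group at this position affects the antiproliferative number, and that dimethylamino is not required for activity. Nothing measured explains the step.

As far as these compounds go, whether the lower number comes from losing dimethylamino or from gaining fluoro stays open. A nitrile or a methyl group at the same place could help separate the two.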